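Azetidine carbonyl variation in a chloro-aryl oxadiazole series

The source may report more compounds than this note shows. Statements on the series, on what has been measured and on what is new or still open speak of the compounds shown alone.

Three compounds of a shared core have numbers in an assay on HEK293 cells for positive allosteric modulation of metabotropic glutamate receptor 5 (Homo sapiens), read by FLIPR; on this read-out lower numbers stand for an effect already at smaller amounts and higher numbers for an effect only at larger amounts of compound. Compound 1 `O=C(C1CCC(F)(F)CC1)N1CC(c2nc(-c3cccc(F)c3)no2)C1` gives 520 nM. Compound 3 `O=C(N1CCCCCC1)N1CC(c2nc(-c3cccc(Cl)c3)no2)C1` gives 47 nM. For compound 2 `Cc1cccc(-c2noc(C3CN(S(=O)(=O)c4cccc(C)c4)C3)n2)c1` the result is only a limit of the assay, > 10000 nM, as the limit of > 10000 nM in this assay, at which 1 of the 3 values shown sits, records.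

Among the two numbers shown, compound 3 stands lowest; the nearest number, that of compound 1, lies well beyond the usual scatter above it. Among the measured compounds shown here, no step between two measured compounds differs in one place, so no measured step guides the next move directly.

Compound 4 `O=C([C@@H]1CC2CCC1C2)N1CC(c2nc(-c3cccc(Cl)c3)no2)C1` is not yet measured in this assay. It differs from compound 3 as follows: a group of 7 heavy atoms (7 carbon; 2 five-membered non-aromatic rings of carbon only) in place of a group of 7 heavy atoms (6 carbon, 1 nitrogen; one seven-membered non-aromatic ring with 1 hetero atom), on a carbonyl carbon.

Since the replaced group keeps the size of seven heavy atoms and both partners are saturated rings without donors or acceptors, the step in this assay from compound 3 to compound 4 is expected to be small, likely a modest rise in the number, though a result within the scatter would not surprise. The estimated step is a 2.3-fold higher number from compound 3 to compound 4 (0.37 log units; beyond the scatter). Compound 4 is expected to give about 110 nM, within 30 nM to 400 nM.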

Compound 4, half-maximal effective concentration: 98 nM
Compound 4: middle estimate off by 1.1-fold (0.05 log units), on the high side, within the range that was stated.
By their numbers in this assay, from the lowest: compound 3; then compound 4; then compound 1. At a limit, above all of these: compound 2.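

Among the compounds shown here, at the carbonyl carbon, azepan-1-yl gives way to a group of carbon only, with 2 five-membered non-aromatic rings, and this assay records a 2.1-fold higher number from compound 3 to compound 4 (0.32 log units; beyond the scatter) as the first step between two compounds that differ in one place. Compound 4 has no nitrogen in this group and still gives 98 nM, so a ring nitrogen on the carbonyl carbon is not needed for a result of this order, although the modest step lies beyond the usual scatter. Nothing measured here gives a reason for this step.

Still open, on these data alone, is how the number responds to the opposite configuration at the defined stereocentre of compound 4, or to a piperidin-1-yl ring or an open diethylamino group on the same carbonyl carbon. The role of the halogen on the aryl ring also remains unresolved, since no pair shown isolates it, and a methoxy group in place of the chlorine of compound 3 would test that part of the structure alone.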